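The compounds below may be only part of what the source reports. "The series", "measured", "known", "first", "only" and "open" are said of these compounds alone.

Measured compounds in a functional assay on HepG2 cells (Homo sapiens) for antiproliferative activity, read by CCK-8 assay, with a stated time of 24 h; a lower number here means a stronger inhibitor, a higher number a weaker inhibitor:
Compound 1 `COC(=O)[C@]1(Cc2ccc3c(c2)CC(C(C)(C)O)O3)OC(=O)C(O)=C1c1ccccc1` gives > 20000 nM, a limit of the assay.
Compound 2 `COC(=O)[C@]1(Cc2ccc(O)c(CC=C(C)C)c2)OC(=O)C(O)=C1c1ccccc1` gives 12900 nM.
Compound 3 `COC(=O)[C@]1(Cc2ccc3c(c2)C[C@H](O)C(C)(C)O3)OC(=O)C(O)=C1c1ccc(O)cc1` gives > 20000 nM, a limit of the assay.

Compound 3 thus stands at the limit rather than at a number, and the marked feature of the set is the limit of > 20000 nM in this assay, at which 2 of the 3 values shown sit. Compound 2 is the only one of the three with a number. Compound 4 `COC(=O)[C@]1(Cc2ccc3c(c2)CCC(C)(C)O3)OC(=O)C(O)=C1c1ccc(O)cc1` differs from compound 3 by hydrogen in place of hydroxy on a saturated ring carbon. Going by the values given here, no measured step connects any pair here, so the size of the step in this assay is open; nothing among the measured compounds argues for a large shift in either direction, and a result at or near the limit seems likeliest. Compound 4 is therefore expected to give 20000 nM, between 8000 nM and 50000 nM. That estimate means a step of a number no higher from compound 3 to compound 4 (the limit leaves the size open), to be read loosely since compound 3 offers only a limit.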

Compound 4, half-maximal inhibitory concentration: > 20000 nM
Compound 4: no number, only a limit; the forecaster's own chance of this, stated with the estimate: 60%; the middle value lies on the limit itself.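

No step can be read from compound 3 to compound 4, because both values are limits of the assay: the limit of > 20000 nM in this assay, at which 3 of the 4 values shown sit. Going by these compounds, whether hydrogen in place of hydroxy on a saturated ring carbon shifts antiproliferative activity remains open.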